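The source may report more compounds than this note shows. Statements on the series, on what has been measured and on what is new or still open speak of the compounds shown alone.

Compound 2 `Cc1cc(C2=CC(=O)N3C[C@H](O[C@H](C)c4cc(C(F)(F)F)cc(C(F)(F)F)c4)[C@@H](c4ccc(F)cc4)C3C2)ccn1` gives the lowest of the two numbers recorded in an assay on CHO cells for displacement of a labelled ligand from Substance-P receptor (Homo sapiens), in the presence of a further agent that is not named here (on this read-out lower numbers stand for stronger inhibition and higher numbers for weaker inhibition), namely 34 nM. For the measured compounds named here, its nearest neighbour is compound 1 `C[C@@H](O[C@H]1CN2C(=O)C=C(c3ccc(C#N)cc3)CC2[C@@H]1c1ccc(F)cc1)c1cc(C(F)(F)F)cc(C(F)(F)F)c1`, which in this assay gives 53 nM; the only step measured so far, a 1.6-fold lower number from compound 1 to compound 2 (0.19 log units; within the scatter), exchanges one aromatic ring for another on the double-bonded ring carbon of the shared core and stays within the scatter. Compound 3 `C[C@@H](O[C@H]1CN2C(=O)C=C(C3=CCC(O)CC3)CC2[C@@H]1c1ccc(F)cc1)c1cc(C(F)(F)F)cc(C(F)(F)F)c1` is not yet measured. It differs from compound 2 in that (4-hydroxycyclohex-1-en-1-yl in place of 2-methylpyridin-4-yl on a double-bonded ring carbon). Going by the values given here, no measured step bears directly on this change: the one step available swaps an aromatic ring for an aromatic ring, whereas here an aromatic ring gives way to a non-aromatic one carrying a hydrogen-bond donor. Among the compounds with values here, the single step shows that the group on this carbon can be varied without a shift beyond the scatter, but it gives no guide to a non-aromatic replacement. A modest rise in the number is therefore expected for compound 3, of about a 3.2-fold higher number from compound 2 to compound 3 (0.51 log units; beyond the scatter), with wide uncertainty. The estimate for compound 3 in this assay is 110 nM, expected to lie between 30 nM and 450 nM.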

Compound 3, half-maximal inhibitory concentration: 13 nM
Compound 3: the middle estimate sits 8.5-fold (0.93 log units) above what was measured; the whole stated range lies above it.
By their numbers in this assay, from the lowest: compound 3; then compounds 2 and 1 (each within the scatter of the next).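

At this position, a non-aromatic ring carrying a hydroxyl group is not merely tolerated in this assay: 4-hydroxycyclohex-1-en-1-yl gives a 2.6-fold lower number from compound 2 to compound 3 (0.42 log units; beyond the scatter) and, against the nitrile-bearing ring, a 4.1-fold lower number from compound 1 to compound 3 (0.61 log units; beyond the scatter). Both steps lie beyond the scatter, whereas the exchange of one aromatic ring for another had not, so among these three compounds an aromatic ring on the double-bonded ring carbon is not needed for the lowest number, which belongs to compound 3. No evidence is available to explain this change in the number.

The compounds shown do not separate the contribution of the hydroxyl group from that of the non-aromatic ring, as they include neither a cyclohexenyl ring without the hydroxyl group nor one bearing an amine or a carboxylic acid in its place. They also leave open how a fully saturated cyclohexyl ring or a hydroxymethyl group on the same ring would read in this assay.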